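Epimer at the chain carbon of a sulfonium glycosidase inhibitor

This account rests on a few compounds, and the source may have more. Where it says the series, first, only, none or still open, it means among the compounds named here.

Measured so far in an assay on isolated protein for inhibition of lysosomal alpha-glucosidase (Rattus norvegicus); a higher number here means a weaker inhibitor, a lower number a stronger inhibitor:
- compound 1, `OC[C@H](O)C[S@+]1C[C@@H](O)[C@H](O)[C@H]1CO`: > 384000 nM (a limit, not a number)
- compound 2, `OC[C@@H]1[C@@H](O)[C@H](O)C[S@@+]1C[C@@H](O)[C@@H](O)[C@H](O)[C@H](O)[C@@H](O)CO`: 4800 nM

Compound 1 returns only a limit in this assay, so it stands at the limit of > 384000 nM in this assay, at which 1 of the 2 values shown sits, and no number is known for it. Compound 2, the analogue carrying the longer open chain on the sulfur, gives a measured value in this assay, as shown above. Among the measured compounds shown here, no step between compounds that differ in one place has been measured, so no measured step size is available.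

Compound 3, `OC[C@@H](O)C[S@+]1C[C@@H](O)[C@H](O)[C@H]1CO`, is the epimer of compound 1: the two compounds have the same atoms and bonds and differ only in configuration as drawn: 1 of 5 stereo elements differ; a stereocentre at a saturated chain carbon is drawn S in compound 1 and R in compound 3. With compound 1 only a limit in this assay, the direction of the step cannot be fixed from the numbers; the expectation is that inverting a single chain stereocentre, with the ring and the chain length unchanged, leaves a weak inhibitor, so a step of an at least 1.2-fold lower number from compound 1 to compound 3 (0.10 log units; that floor lies within the scatter) is estimated, toward stronger inhibition at most by a modest amount. Compound 3 is expected at 300000 nM, with a range of 50000 nM to 2000000 nM, and a fair chance that this assay again reports only a limit.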

Compound 3, half-maximal inhibitory concentration: 105000 nM
The estimate for compound 3 lay 2.9-fold (0.46 log units) above the measured number, within the range that was stated.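

In this assay, among the compounds shown here, the chain stereocentre proves to be a position the read-out responds to, with inversion from S to R alone giving an at least 3.6-fold lower number from compound 1 to compound 3 (0.56 log units; beyond the scatter); the earlier compounds offered no comparison of this kind, since no step between compounds differing in one place was available. The size of this step is only a floor, and compound 1 enters it as a limit rather than a number: the limit of > 384000 nM in this assay, at which 1 of the 3 values shown sits. The step can be assigned to the configuration at this chain carbon, with no other structural change involved, because of one fact: the fact that compounds 1 and 3 differ only in the configuration as drawn

As far as these compounds go, the true size of the step remains open, as does whether the R configuration would keep its advantage on the longer open chain of compound 2 or at the other stereo elements of the series. Also open is how this chain stereocentre would behave if an amine or a carboxylic acid took the place of a chain hydroxyl, since the compounds shown carry only hydroxyl groups on the chain.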